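Adding a Second Trifluoromethyl to Compound 2

A few compounds are considered here, and "the series" means these few. Any claim that something is new, unique, unknown or untested is made for them only; others in the source may bear on it.

Within the data shown here, compound 2 `COc1cc(NC(=O)c2cccc(C(F)(F)F)c2)ccc1NS(=O)(=O)C(F)(F)F` is the only compound for which an ADME assay on RAW264.7 cells (Mus musculus) for cytotoxicity, read by MTT assay, with a stated time of 48 h (a lower number here means a stronger inhibitor, a higher number a weaker inhibitor), returns a number: in this assay compound 2 gives 75200 nM. Compound 1 `COc1cc(NC(=O)c2cc(C(F)(F)F)cc(C(F)(F)F)c2)ccc1NS(C)(=O)=O` reaches only a limit in this assay; compound 1 gives > 250000 nM, which is a limit of the assay and not a number. The evidence is simply (the limit of > 250000 nM in this assay, at which 1 of the 2 values shown sits).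

Compound 3 `COc1cc(NC(=O)c2cc(C(F)(F)F)cc(C(F)(F)F)c2)ccc1NS(=O)(=O)C(F)(F)F` has not yet been measured and differs from compound 2 in one place: trifluoromethyl in place of hydrogen on an aromatic carbon. Among the measured compounds shown here, no step between two measured compounds is available here, so the size of this change cannot be read from a measured pair. What the two values show is that compound 1, carrying the same pair of trifluoromethyl groups as compound 3, sits at the limit, while compound 2, with a single trifluoromethyl group, gives a number.

The step of a 2.1-fold higher number from compound 2 to compound 3 (0.33 log units; beyond the scatter) is expected to run toward weaker inhibition and to lie beyond the usual scatter. For compound 3 the estimate in this assay is 160000 nM, within 50000 nM to 500000 nM, with a real chance that only a limit is reported.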

Compound 3, half-maximal inhibitory concentration: > 250000 nM
Compound 3: no number, only a limit (the forecaster's own chance of this, stated with the estimate: 40%); middle value at least 1.5-fold (0.19 log units) from the limit.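

At this aromatic carbon, meta to a trifluoromethyl group, trifluoromethyl in place of hydrogen now has a readable direction in this assay: the change runs toward weaker inhibition, with an at least 3.3-fold higher number from compound 2 to compound 3 (0.52 log units; beyond the scatter), and this step is only a lower bound on its true size. Compound 3 gives > 250000 nM, which is a limit of the assay and not a number. With this result, the pair of trifluoromethyl groups appears at the limit with both sulfonyl substituents shown, and the one compound with a number carries a single trifluoromethyl group, so the full size of the step stays out of reach: the limit of > 250000 nM in this assay, at which 2 of the 3 values shown sit.

The step between compound 1 and compound 3, trifluoromethyl in place of methyl on the sulfonyl sulfur, cannot be read, and the compounds shown therefore leave open whether that change has any effect when two trifluoromethyl groups are present. Also open, from the compounds shown here alone, is how a different group at this aromatic carbon, such as a nitrile, a chlorine atom or an amine, would compare with hydrogen and with trifluoromethyl, and whether it would return a number rather than a limit.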